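Pyridin-2-yl to pyridin-4-yl: a small step expected

The source may hold more compounds than are shown below. What is called first, only, known or untested is meant among the compounds shown, and "the series" means these compounds.

compound 1 `CCCC(=O)CC(=O)N1CCSC1COc1ccccc1OC` gives 42 mg/kg
compound 2 `COc1ccccc1OCC1SCCN1C(=O)CC(=O)NCc1ccccn1` gives 26 mg/kg

Among the compounds with values here, in a functional assay on the whole organism for inhibition, with Cavia porcellus as the target (a higher number here means that more compound is needed for the effect, a lower number that less compound is needed), compound 2 cannot be told apart from compound 1, the only other compound measured, as the data show a 1.6-fold lower number from compound 1 to compound 2 (0.21 log units; within the scatter). Compound 3 `COc1ccccc1OCC1SCCN1C(=O)CC(=O)NCc1ccncc1` carries pyridin-4-yl in place of pyridin-2-yl on a saturated chain carbon bound to an amide-type nitrogen. Within the data shown here, no measured step covers this exchange. Among the measured compounds shown here, the one available step, which brought in the ((pyridin-2-yl)methyl)amino group, stayed within the scatter, so no change beyond the scatter, and no particular direction, is expected in this assay. The estimated change is no change at the digits printed from compound 2 to compound 3 (within the scatter). For compound 3 the expected value is 26 mg/kg, with an estimated range from 11 mg/kg to 60 mg/kg.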

Compound 3, dose for half-maximal effect: 23 mg/kg
The estimate for compound 3 lay 1.1-fold (0.05 log units) above the measured number; the measured number falls inside the stated range.
By their numbers in this assay, from the lowest: compounds 3, 2 and 1 (each within the scatter of the next).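

Putting pyridin-4-yl in place of pyridin-2-yl on a saturated chain carbon bound to an amide-type nitrogen gave, in this assay, a 1.1-fold lower number from compound 2 to compound 3 (0.05 log units; within the scatter), so the two groups cannot be told apart at this place. The exchange of propyl on a carbonyl carbon for ((pyridin-4-yl)methyl)amino gave a 1.8-fold lower number from compound 1 to compound 3 (0.26 log units; within the scatter), so it too shows no measurable change. No evidence bears on this result. Going by these compounds, whether pyridin-3-yl or a plain phenyl at this place would shift the number beyond the scatter remains open.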